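The source may report more compounds than this note shows. Statements on the series, on what has been measured and on what is new or still open speak of the compounds shown alone.

Measured so far in an assay on membranes from brain (Cavia porcellus) for binding affinity to Sigma non-opioid intracellular receptor 1 (Homo sapiens), read by radioligand binding; on this read-out higher numbers stand for weaker inhibition and lower numbers for stronger inhibition:
Compound 1 `CN(C(=N)N(c1ccccc1)c1cccc2ccccc12)c1cccc2ccccc12` gives 11000 nM.
Compound 2 `CCc1cccc(NC(=N)Nc2cccc3ccccc23)c1` gives 54 nM.
Compound 3 `Cc1cccc(NC(=N)Nc2cccc3ccccc23)c1` gives 75 nM.

Compound 2 has the lowest number of the three in this assay. Its nearest neighbour is compound 3, reached by a 1.4-fold higher number from compound 2 to compound 3 (0.14 log units; within the scatter), a change that stays within the scatter. Compound 1 stands far away at the other end, with a number well beyond the scatter from that of compound 2.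

Compound 4 `CCc1cccc(N(CC)C(=N)Nc2cccc3ccccc23)c1` has not been measured. It differs from compound 2 by ethyl in place of hydrogen on a nitrogen on an aromatic ring. Within the data shown here, no measured step covers this change directly: the step from compound 2 to compound 3 concerns a methyl in place of an ethyl, not the nitrogen, and says little here. Among the measured compounds shown here, the only hint comes from compound 1, which carries more groups on the shared core than compound 2 and whose number in this assay is far higher. On that basis a move toward higher numbers is expected for compound 4 in this assay, of about a 9.3-fold higher number from compound 2 to compound 4 (0.97 log units; beyond the scatter), with wide uncertainty. Compound 4 is therefore estimated at 500 nM, between 100 nM and 3000 nM.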

Compound 4, half-maximal inhibitory concentration: 2190 nM
For compound 4 the middle estimate is 4.4-fold (0.64 log units) below the measured one; measured number inside the range.
By their numbers in this assay, from the lowest: compounds 2 and 3 (each within the scatter of the next); then compound 4; then compound 1.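

In this assay, putting an ethyl in place of the hydrogen on this nitrogen gives a 41-fold higher number from compound 2 to compound 4 (1.61 log units; beyond the scatter), a large step beyond the scatter. This is the first single change shown at this nitrogen, whereas compound 1 differs from compound 2 in several places at once and so could not single it out; the only earlier single change, on a saturated chain carbon bound to an aromatic carbon, gave a 1.4-fold higher number from compound 2 to compound 3 (0.14 log units; within the scatter) and stayed within the scatter. Nothing shown here explains why the ethyl on this nitrogen goes with so much higher a number.

The compounds shown leave open whether a different group on this nitrogen, such as a propyl chain or an acetyl, would give a number like that of compound 4. They also leave open whether the same ethyl on the other nitrogen of the shared core would give a step of similar size.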